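Methyl on the Hydroxy Oxygen of Compound 2

The source may report more compounds than this note shows. Statements on the series, on what has been measured and on what is new or still open speak of the compounds shown alone.

In a functional assay on DWD cells (Homo sapiens) for inhibition, read by sulforhodamine B assay (a lower number here means a stronger inhibitor of growth, a higher number a weaker inhibitor of growth), compound 1 `Oc1cccc2[nH]c(-c3ccc(-c4ccc(-c5ccc(C(F)(F)F)cc5)cc4)cc3)nc12` gives 3180 nM and compound 2 `Oc1ccc(-c2ccc(-c3ccc(-c4nc5c(O)cccc5[nH]4)cc3)cc2)cc1` gives 2700 nM, two numbers within the scatter of each other. Compound 3 `COc1ccc(-c2ccc(-c3ccc(-c4nc5c(O)cccc5[nH]4)cc3)cc2)cc1` differs from compound 2 by methyl in place of hydrogen on an oxygen on an aromatic ring, with methyl in place of hydrogen on an oxygen on an aromatic ring, so that 4-hydroxyphenyl becomes 4-methoxyphenyl. Within the data shown here, the one measured step that bears on this, a 1.2-fold lower number from compound 1 to compound 2 (0.07 log units; within the scatter), exchanged trifluoromethyl for hydroxy and stayed within the scatter, so no step beyond the scatter is expected in this assay. The estimated step is a 1.0-fold higher number from compound 2 to compound 3 (0.02 log units; within the scatter). For compound 3 the expected value is 2800 nM, with an estimated range of 1300 nM to 6000 nM.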

Compound 3, concentration for 50% growth inhibition: 6400 nM
For compound 3 the middle estimate is 2.3-fold (0.36 log units) below the measured one; measured number outside the range, above it.
By their numbers in this assay, from the lowest: compounds 2, 1 and 3 (each within the scatter of the next, the first and the last beyond it).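

In this assay, methyl on the oxygen gives a 2.4-fold higher number from compound 2 to compound 3 (0.37 log units; beyond the scatter), the first step among these compounds to lie beyond the scatter, so this oxygen on an aromatic ring does respond to a change. Methoxy in place of trifluoromethyl gives a 2.0-fold higher number from compound 1 to compound 3 (0.30 log units; within the scatter), so that exchange cannot separate compound 1 from compound 3. Nothing measured here accounts for the step. As far as these compounds go, what remains open is how an amine or a carboxylic acid in place of hydroxy would read, and whether ethoxy, a longer chain on the oxygen, would move the number further.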